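Ring Amine in Place of Chain Amine: Cytotoxicity Outlook

The compounds below may be only part of what the source reports. "The series", "measured", "known", "first", "only" and "open" are said of these compounds alone.

Of the compounds shown here, three on a shared core have been measured in an ADME assay on Vero cells (Chlorocebus sabaeus) for cytotoxicity, read by WST assay; on this read-out higher numbers stand for lower toxicity in this test and lower numbers for higher toxicity in this test. Compound 1 `O=c1[nH]c(Nc2cc(F)cc(F)c2)nc2cc(Cl)ccc12` gives >= 18000 nM, which is a limit of the assay rather than a number. Compound 2 `O=c1[nH]c(Nc2cccc(C(F)(F)F)c2)nc2cc(Cl)ccc12` gives > 25000 nM, again a limit. Compound 3 `CC(C)Nc1nc2cc(Cl)ccc2c(=O)[nH]1` gives > 25000 nM, also a limit. Compound 3 thus stands with the others at the edge of what this assay reports, as the limit of > 25000 nM in this assay, at which 2 of the 3 values shown sit, and the limit of >= 18000 nM in this assay, at which 1 of the 3 values shown sits, show, and no step beyond the usual scatter is known among them. Compound 4 `O=c1[nH]c(N2CCCCC2)nc2cc(Cl)ccc12` differs from compound 3 by piperidin-1-yl in place of isopropylamino on an aromatic carbon. Going by the values given here, no measured step covers such a change, so the step that the limit leaves unreadable from compound 3 to compound 4 is expected to stay within the scatter. Compound 4 is therefore estimated at 30000 nM, with a range from 12000 nM to 80000 nM, and most likely reported again as a limit.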

Compound 4, half-maximal cytotoxic concentration: > 25000 nM
Compound 4 was reported as a limit; the forecaster's own chance of this, stated with the estimate: 80%; the middle value does not contradict the limit.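

Going by these compounds alone, compound 3 and compound 4 both give only a limit of the assay, and no step between them can be read. Whether any of the four compounds shown reaches a measurable toxic concentration in this assay stays open.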